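The source may hold more compounds than are shown below. What is called first, only, known or untested is meant among the compounds shown, and "the series" means these compounds.

In a functional assay on PC-3 cells (Homo sapiens) for cytotoxicity, read by MTT assay, with a stated time of 72 h (a higher number here means a weaker inhibitor, a lower number a stronger inhibitor), the measurements so far are:

- Compound 1 `CCC[C@H](Nc1cncc(-c2ccc(O)c(OC)c2)n1)c1ccccc1`: 160 nM
- Compound 2 `CCCC(Nc1cncc(-c2ccc(O)c(OC)c2)n1)c1ccccc1`: 160 nM

Among the measured compounds shown here, compound 2 gives 160 nM, level with its only measured neighbour: no change at the digits printed from compound 1 to compound 2 (within the scatter). These two compounds share the same atoms and bonds, and what separates them is the fact that one of compounds 1 and 2 is drawn with a defined configuration and the other without, at the place where they differ.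

The next compound, compound 3 `CCCC(Nc1cncc(-c2ccc(O)c(OC)c2)n1)c1cccc(OC)c1`, keeps the rest of compound 2 but turns phenyl into 3-methoxyphenyl: methoxy in place of hydrogen on an aromatic carbon. In words, a methoxy group takes the place of hydrogen on an aromatic carbon.

For the measured compounds named here, only one measured step exists, no change at the digits printed from compound 1 to compound 2 (within the scatter), and it concerns how a stereocentre is drawn, not a new group on a ring. It therefore gives no measured size or direction for adding a methoxy group. With no evidence favouring either direction, the central expectation in this assay is no shift beyond the scatter, though the uncertainty is wide on both sides. The expected change is no change at the digits printed from compound 2 to compound 3 (within the scatter).

For compound 3, the estimated value is 160 nM, with an expected range from 50 nM to 500 nM.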

Compound 3, half-maximal inhibitory concentration: 10000 nM
The estimate for compound 3 lay 63-fold (1.80 log units) below the measured number; the whole stated range lies below it.
By their numbers in this assay, from the lowest: compounds 1 and 2 (each within the scatter of the next); then compound 3.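

Compounds 1 and 2 differ only in how a stereocentre is drawn, so they said nothing about the phenyl ring itself. In this assay, putting a methoxy group in place of hydrogen on an aromatic carbon of that ring, meta to a large group, gives a 63-fold higher number from compound 2 to compound 3 (1.80 log units; beyond the scatter), which shows that activity in these cells is highly sensitive to this change at this position, even though only two heavy atoms enter. What is known so far concerns only the drawing of the stereocentre and has no bearing on this step, so nothing here accounts for the weaker result.

From the compounds shown here alone, it remains open whether this loss is specific to methoxy or would also follow from another group on the same carbon, such as a fluorine, a methyl or a hydroxyl. Going by these compounds, it is equally open whether a methoxy group on one of the other carbons of this ring would be as damaging, or whether the phenyl ring can take any addition at all.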